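The source may hold more compounds than are shown below. What is called first, only, known or untested is meant among the compounds shown, and "the series" means these compounds.

Measured compounds:

Compound 1, `CCOc1cc(=O)n(CCCO)c2c1CC(CC=C(C)C)C(C)(C)C2`: 16.6%
Compound 2, `CC(C)=CCC1Cc2c(OCCCNS(=O)(=O)c3ccc(Br)cc3)cc(=O)n(CCCO)c2CC1(C)C`: 3.7%
Compound 3, `COc1ccc(C(=O)NCCCOc2cc(=O)n(CCCO)c3c2CC(CC=C(C)C)C(C)(C)C3)cc1`: 2.5%

In a functional assay on PANC-1 cells (Homo sapiens) for inhibition, read by MTT assay, with a stated time of 24 h, tested at 10 uM (a lower number here means less inhibition, a higher number more inhibition at the concentration tested (going by the name of the read-out)), compound 1 gives 16.6%, the highest of the three numbers. Compound 2 and compound 3 both sit lower: a number 12.9 percentage points lower from compound 1 to compound 2 (beyond the scatter) and a number 14.1 percentage points lower from compound 1 to compound 3 (beyond the scatter). Between compound 2 and compound 3 the difference is small, a number 1.2 percentage points lower from compound 2 to compound 3 (within the scatter). In both measured steps, a group carrying an aromatic ring was added on the chain that hangs from the oxygen on the aromatic ring of the shared core, and each time the inhibition fell by a modest amount.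

Compound 4, `CC(C)=CCC1Cc2c(OC(=O)Nc3ccc(F)cc3)cc(=O)n(CCCO)c2CC1(C)C`, is not yet measured. Relative to compound 1 it changes at that same oxygen: (4-fluorophenyl)carbamoyl in place of ethyl on an oxygen on an aromatic ring. Here too a group with an aromatic ring enters at the oxygen, though attached directly rather than along a longer chain. The two measured steps from compound 1 are the closest guide, and both point downward, so a fall of similar size is expected in this assay, a number 11.6 percentage points lower from compound 1 to compound 4 (beyond the scatter). Compound 4 is therefore estimated at 5%, with a range from 0% to 15%.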

Compound 4, a percentage reported as inhibition, at one concentration (the size of the read-out at that concentration, not a potency): 0%
The estimate for compound 4 lay 5 percentage points above the measured number, within the range that was stated.
By their numbers in this assay, from the lowest: compounds 4, 3 and 2 (each within the scatter of the next); then compound 1.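

In this assay, placing (4-fluorophenyl)carbamoyl instead of ethyl on this oxygen gives a number 16.6 percentage points lower from compound 1 to compound 4 (beyond the scatter), and compound 4 reads 0%, leaving no inhibition to see at the concentration tested. This shows that the downward step at this oxygen also occurs when the aromatic ring is joined through a carbamoyl group rather than a longer chain, and the values of compounds 2, 3 and 4 lie too close for this difference in linkage to separate them. No measurement here explains the fall.

Going by these compounds, it remains open whether a hydrogen or methyl on this oxygen, or a plain amine at the end of the chain with no aromatic ring, would match or exceed compound 1. The effect of a longer saturated chain without a ring is equally unknown.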